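Hydroxyethyl amide to methoxy(methyl) amide in a whole-animal screen

The source may report more compounds than this note shows. Statements on the series, on what has been measured and on what is new or still open speak of the compounds shown alone.

Measured compounds:
compound 1 `O=C(/C=C1\CCc2ccc(F)cc21)NCCO`, 50%
compound 2 `NC(=O)/C=C1\CCc2c(Cl)cccc21`, 67%

Of the compounds shown here, two have been tested in a functional assay on the whole organism with Mus musculus as the target, at a dose of 100 mg/kg by the intraperitoneal route; on this read-out higher numbers stand for more inhibition at the one dose given (going by the name of the read-out) and lower numbers for less inhibition. Compound 1 gives 50%, the lower of the two numbers; compound 2 reaches 67%, a gap that lies beyond the usual scatter. Compound 3 `CON(C)C(=O)/C=C1\CCc2ccc(F)cc21` is not yet measured. It differs from compound 1 in one place: methoxy(methyl)amino in place of (2-hydroxyethyl)amino on a carbonyl carbon. For the measured compounds named here, no step between measured compounds matches this change, so the expected step of a number 8 percentage points lower from compound 1 to compound 3 (within the scatter) in this assay is small and its direction uncertain. Compound 3 is therefore estimated at 42%, within 15% to 70%.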

Compound 3, a percentage reported as inhibition, in the whole organism at one dose (the size of the read-out at that dose, not a potency): 17%
The estimate for compound 3 lay 25 percentage points above the measured number; measured number inside the range.
By their numbers in this assay, from the lowest: compound 3; then compound 1; then compound 2.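

In this assay, replacing (2-hydroxyethyl)amino with methoxy(methyl)amino on the carbonyl carbon is a large step, a number 33 percentage points lower from compound 1 to compound 3 (beyond the scatter). This shows that the read-out responds to the group at this position, even when the two groups have the same heavy atoms. The entering group has 0 hydrogen-bond donors against 2 for the leaving group, but no measurement ties the step to that difference or to any other cause. The compounds shown leave open whether methoxyamino or dimethylamino on the same carbonyl carbon would stay close to compound 1 or fall towards compound 3. Such a pair would separate the amide hydrogen from the rest of the change.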